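Aryl swap on the fused core of compound 1

A few compounds are considered here, and "the series" means these few. Any claim that something is new, unique, unknown or untested is made for them only; others in the source may bear on it.

Compound 1 `C=C(C)[C@H]1CC=C(C)[C@@]2(O)[C@@H]1[C@H](c1ccc(Cl)cc1Cl)O[C@@H]2C(=O)OCC` is tested in a functional assay on KB3 cells (Homo sapiens) for antiproliferative activity, read by MTT assay, with a stated time of 96 h (a lower number here means a stronger inhibitor, a higher number a weaker inhibitor), where compound 1 gives 3000 nM. Two further compounds with related cores are known. Compound 2 `C=C(C)[C@H]1CC=C(C)C2=CO[C@@H](c3ccco3)[C@@H]21` carries a furan in place of a substituted phenyl and gives 2000 nM; compound 3 `C=C(C)[C@H]1CC(=O)C(C)=C2[C@@H](C(=O)OCC)O[C@@H](c3cccc(Br)c3)[C@@H]21` carries a 3-bromophenyl on a core with a ketone instead of the hydroxy group and gives 30000 nM. On these three numbers compound 1 stands second highest: the gap to compound 2 lies within the usual scatter, so no order between the two can be claimed, while the gap to compound 3 is well beyond it and compound 3 is clearly the weaker of that pair.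

Compound 4 `C=C(C)[C@H]1CC=C(C)[C@@]2(O)[C@@H]1[C@H](c1ccccc1Br)O[C@@H]2C(=O)OCC` differs from compound 1 in one place: 2-bromophenyl in place of 2,4-dichlorophenyl on a saturated ring carbon. Within the data shown here, no pair of measured compounds differs in exactly one place, so no measured step informs this change directly. The only other halogenated phenyl in the set sits on compound 3, whose different core makes its value of limited use here. The expectation is a modest move to a higher number, as estimated by a 1.7-fold higher number from compound 1 to compound 4 (0.22 log units; within the scatter), likely not beyond the scatter. Compound 4 is expected to give 5000 nM in this assay, with a range from 1500 nM to 15000 nM.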

Compound 4, half-maximal inhibitory concentration: 20000 nM
For compound 4 the middle estimate is 4.0-fold (0.60 log units) below the measured one, and the stated range ends below it.
By their numbers in this assay, from the lowest: compounds 2 and 1 (each within the scatter of the next); then compounds 4 and 3 (each within the scatter of the next).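

In this assay, among these compounds, the aryl group on the saturated ring carbon next to the ring oxygen proves to be a position that matters: 2-bromophenyl in place of 2,4-dichlorophenyl gives a 6.7-fold higher number from compound 1 to compound 4 (0.82 log units; beyond the scatter), the first step that can be read on a single change, and it lies beyond the scatter. With the hydroxy group, the ethoxycarbonyl group and the rest of the core of compound 1 held fixed, a change in this aryl group alone is enough to shift the number, so these two halogenated phenyl groups are not interchangeable here. The swap alters the halogen and the number of halogens together, so this one step cannot separate the two, and nothing available explains the shift.

Still open, from the compounds shown here alone, is where 2-chlorophenyl, 4-chlorophenyl, 2-bromo-4-chlorophenyl or unsubstituted phenyl would fall on this core, which would separate the halogen from its count. Also open, going by these compounds, is how the number responds at the other places on the core, for example with a carboxylic acid or an amide in place of the ethoxycarbonyl group.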